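Exchanging 4-methylphenyl for 2-chlorophenyl on a shared core

The source may report more compounds than this note shows. Statements on the series, on what has been measured and on what is new or still open speak of the compounds shown alone.

Measured in a functional assay on HeLa cells (Homo sapiens) for cytotoxicity, read by MTT assay, with a stated time of 48 h; on this read-out higher numbers stand for weaker inhibition and lower numbers for stronger inhibition:
Compound 1 `COc1cc(/C=C/C(=O)C2=C(/C=C/c3ccc(O)c(OC)c3)NC(=O)NC2c2ccccc2O)ccc1O`: 50000 nM
Compound 2 `COc1cc(/C=C/C(=O)C2=C(/C=C/c3ccc(O)c(OC)c3)NC(=O)NC2c2ccccc2Cl)ccc1O`: 100000 nM
Compound 3 `COc1cc(/C=C/C(=O)C2=C(/C=C/c3ccc(O)c(OC)c3)NC(=S)NC2c2ccc(C)cc2)ccc1O`: 25000 nM

Compound 3 , at 25000 nM, lies within the scatter of compound 1 , and its number is beyond the scatter below that of compound 2 . Compound 4 `COc1cc(/C=C/C(=O)C2=C(/C=C/c3ccc(O)c(OC)c3)NC(=S)NC2c2ccccc2Cl)ccc1O` differs from compound 3 in one place, with 2-chlorophenyl in place of 4-methylphenyl on a saturated ring carbon. Within the data shown here, no measured step covers this exchange directly. Among the measured compounds shown here, the only measured step, a 2.0-fold higher number from compound 1 to compound 2 (0.30 log units; within the scatter), puts chloro in place of hydroxy on an aromatic carbon and stays within the scatter, so it offers little reason to expect a large change. Compound 2 also carries 2-chlorophenyl and gives 100000 nM, but it differs from compound 4 elsewhere in the core. That value points to a modest rise in this assay, not clearly beyond the scatter. The expected step is a 1.8-fold higher number from compound 3 to compound 4 (0.26 log units; within the scatter). For compound 4 the estimated value is 45000 nM, with an expected range from 18000 nM to 110000 nM.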

Compound 4, half-maximal inhibitory concentration: 50000 nM
The estimate for compound 4 lay 1.1-fold (0.05 log units) below the measured number; the measured number falls inside the stated range.
By their numbers in this assay, from the lowest: compounds 3, 1, 4 and 2 (each within the scatter of the next, the first and the last beyond it).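

In this assay, exchanging the whole group on a saturated ring carbon gives a 2.0-fold higher number from compound 3 to compound 4 (0.30 log units; within the scatter), so 2-chlorophenyl and 4-methylphenyl cannot be told apart at this position on the shared core of compound 3. Together with the earlier 2.0-fold higher number from compound 1 to compound 2 (0.30 log units; within the scatter), this makes two single exchanges in the group at this carbon, and both stay within the scatter, though the two exchanges sit on different cores and involve different groups. No supporting measurement bears on this result.

The compounds shown leave open whether this position would stay as unresponsive with an amine or a carboxylic acid on the phenyl group. They also leave open what a longer chain in place of the whole aromatic group at this carbon would do.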